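Amide ring change on the shared core of compound 1

This account rests on a few compounds, and the source may have more. Where it says the series, first, only, none or still open, it means among the compounds named here.

Measured so far:
- compound 1 `COc1cc(-c2nc3cc(/C=C4\SC(=O)N(CC(=O)N5CCOCC5)C4=O)ccc3[nH]2)cc(OC)c1OC` — 18800 nM
- compound 2 `COc1cc(OC)c(-c2nc3cc(/C=C4\SC(=O)N(CC(=O)N5CCOCC5)C4=O)ccc3[nH]2)cc1OC` — 35700 nM

In an ADME assay on HEK-293T cells (Homo sapiens) for inhibition, read by MTT assay, with a stated time of 48 h (a lower number here means a stronger inhibitor, a higher number a weaker inhibitor), compound 1 gives 18800 nM, the lowest of the two numbers, while compound 2 gives 35700 nM. The step of a 1.9-fold higher number from compound 1 to compound 2 (0.28 log units; within the scatter) is within the scatter. Compound 3 `COc1cc(-c2nc3cc(/C=C4\SC(=O)N(CC(=O)N5CCCC5)C4=O)ccc3[nH]2)cc(OC)c1OC` differs from compound 1 by pyrrolidin-1-yl in place of morpholin-4-yl on a carbonyl carbon. For the measured compounds named here, no measured step bears on this change; the only measured step, a 1.9-fold higher number from compound 1 to compound 2 (0.28 log units; within the scatter), concerns the trimethoxyphenyl pattern. With nothing measured on the amide ring, the step of no change at the digits printed from compound 1 to compound 3 (within the scatter) is expected to stay within the scatter. Compound 3 is therefore estimated at 18800 nM, with a range from 7500 nM to 47000 nM.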

Compound 3, half-maximal inhibitory concentration: 12700 nM
Compound 3: middle estimate off by 1.5-fold (0.17 log units), on the high side; measured number inside the range.
By their numbers in this assay, from the lowest: compounds 3, 1 and 2 (each within the scatter of the next, the first and the last beyond it).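

In this assay, for the compounds shown here, the amide ring on the carbonyl carbon is tested for the first time: pyrrolidin-1-yl in place of morpholin-4-yl gives a 1.5-fold lower number from compound 1 to compound 3 (0.17 log units; within the scatter) on the shared core. In this pair, the morpholin-4-yl ring and its oxygen can be replaced without a step beyond the scatter. No measured evidence bears on the reason for this result. Still open, on these data alone, is whether piperidin-1-yl, 4-methylpiperazin-1-yl or an open-chain dimethylamino group on the same carbonyl carbon would give a step beyond the scatter.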